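Working notes: from compound 3 to compound 4

The compounds below may be only part of what the source reports. "The series", "measured", "known", "first", "only" and "open" are said of these compounds alone.

Values in a functional assay on SMMC-7721 cells (Homo sapiens) for cytotoxicity, read by MTT assay, with a stated time of 48 h (a higher number here means a weaker inhibitor, a lower number a stronger inhibitor), so far
compound 1 `O=c1cc(-c2ccc(Cl)cc2)oc2ccc(Cn3ccnc3)cc12` gives "not determined" (no result reported)
compound 2 `CN(C)Cc1ccc2c(=O)cc(-c3ccccc3Cl)oc2c1` gives 28200 nM
compound 3 `Cc1cc(Cl)cc2c(=O)cc(-c3ccccc3Cl)oc12` gives "not determined" (no result reported)

Compound 3 has no single number to stand on, since in this assay compound 3 gives "not determined" (no result reported) and nothing more. Compound 4 `O=c1cc(-c2ccccc2Cl)oc2c(Cn3ccnc3)cc(Cl)cc12` is still to be measured. The structural change is 1H-imidazol-1-yl in place of hydrogen on a saturated chain carbon bound to an aromatic carbon, which reads as 1H-imidazol-1-yl in place of hydrogen on a saturated chain carbon bound to an aromatic carbon, or methyl to (1H-imidazol-1-yl)methyl. Compound 1 also carries a (1H-imidazol-1-yl)methyl group, yet compound 1 gives "not determined" (no result reported) and offers no guidance. For the measured compounds named here, no measured step exists in the set. A modest step toward stronger inhibition in this assay is expected, though from an unknown starting point. Going by the values given here, the only anchor is compound 2 at 28200 nM, a single number from a different structure. For compound 4 the estimate is 20000 nM, with an expected range from 6000 nM to 60000 nM in this assay.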

Compound 4, half-maximal inhibitory concentration: 1070 nM
For compound 4 the middle estimate is 19-fold (1.27 log units) above the measured one, and the stated range ends above it.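

In this assay, for the compounds shown here, compound 3 gives "not determined" (no result reported) and so no step from it to compound 4 can be read. No evidence at hand bears on this result. The compounds shown leave open what methyl to (1H-imidazol-1-yl)methyl alone does in this series.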